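Same Small Swap, Tried on a Second Core

This account rests on a few compounds, and the source may have more. Where it says the series, first, only, none or still open, it means among the compounds named here.

Compound 1 `Cc1cc(-n2cc(C(=O)Nc3cc(F)cc(F)c3)c(=O)c3ccc(N(C)C)nc32)ccc1OCCCCCCC[n+]1ccccc1` and compound 2 `CN(C)c1ccc2c(=O)c(C(=O)Nc3cc(F)cc(F)c3)cn(-c3ccc(OCCCCCCC[n+]4ccccc4)c(Cl)c3)c2n1` share one core and differ in a single place: chloro in place of methyl on an aromatic carbon. In an assay on LX2 cells for inhibition of COL1A1 promoter (Homo sapiens), read by a luciferase reporter, with a stated time of 24 h, tested at 50 uM (a lower number here means a weaker effect, a higher number a stronger effect of the compound at the concentration tested), compound 1 gives 55%, while compound 2 gives 21.4%. The step of a number 33.6 percentage points lower from compound 1 to compound 2 (beyond the scatter) is therefore a large loss of effect, well beyond the usual scatter of such measurements.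

Compound 3 `CC[N+]1(CCCCCCCOc2ccc(-n3cc(C(=O)Nc4cc(F)cc(F)c4)c(=O)c4ccc(N(C)C)nc43)c(C)c2)CCCCC1` belongs to a second series; the difference between its core and that of compound 1 is not broken down here. In this assay compound 3 is reported as "not active" (no number reported), so no single number stands for it.

Compound 4 `CC[N+]1(CCCCCCCOc2ccc(-n3cc(C(=O)Nc4cc(F)cc(F)c4)c(=O)c4ccc(N(C)C)nc43)c(Cl)c2)CCCCC1` relates to compound 3 exactly as compound 2 relates to compound 1: chloro in place of methyl on an aromatic carbon. The surroundings of the change are described in the same words for both pairs, so this is the same change made on a second core. It has been measured only once so far, in the pair of compounds 1 and 2.

For the measured compounds named here, the expectation for compound 4 rests on two things: its parent already shows nothing measurable, since compound 3 is reported as "not active" (no number reported), and the one measured instance of the change, a number 33.6 percentage points lower from compound 1 to compound 2 (beyond the scatter), ran downward. Compound 4 is therefore expected to give roughly 5% in this assay, with a likely span from -15% to 25%. There is a fair chance that compound 4 is estimated to come back, like compound 3, without any number at all.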

Compound 4, a percentage reported as inhibition, at one concentration (the size of the read-out at that concentration, not a potency): "not active" (no number reported)
Nothing numeric was reported for compound 4; no gap can be computed for the estimate.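

In this assay, for the compounds shown here, compound 3 stands as "not active" (no number reported) and compound 4 as "not active" (no number reported), so no step from methyl to chloro can be read between these two compounds. Nothing among the data shown bears on this result. The compounds shown leave open whether chloro in place of methyl changes the effect at all on this second core, where neither compound gives a number.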